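The source may report more compounds than this note shows. Statements on the series, on what has been measured and on what is new or still open speak of the compounds shown alone.

Compound 1 `CC(=O)c1ccc2c(c1)nc(-c1ccc(C(F)(F)F)cc1)n2C1CCCCC1`: 35000 nM
Compound 2 `C/C(=N\NC(N)=O)c1ccc2c(c1)nc(-c1ccccc1)n2C1CCCCC1`: > 100000 nM (a limit)

In an ADME assay on Vero cells (Chlorocebus sabaeus) for cytotoxicity, read by MTT assay, with a stated time of 96 h (on this read-out higher numbers stand for lower toxicity in this test and lower numbers for higher toxicity in this test), compound 2 stands at > 100000 nM. On these data alone, this is a limit of the assay and not a number, so the exact position of compound 2 is unknown.

Compound 3 `C/C(=N\NC(N)=O)c1ccc2c(c1)nc(-c1ccc(C(F)(F)F)cc1)n2C1CCCCC1` has not yet been measured. It differs from compound 2 at one place, with trifluoromethyl in place of hydrogen on an aromatic carbon, turning phenyl into 4-(trifluoromethyl)phenyl: trifluoromethyl in place of hydrogen on an aromatic carbon.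

For the measured compounds named here, compound 1 also carries 4-(trifluoromethyl)phenyl and gives 35000 nM, which is the only measured number here. On that basis, a moderate move toward lower numbers in this assay, meaning more toxicity, is expected, though a second limit remains possible. The estimated change is an at least 1.5-fold lower number from compound 2 to compound 3 (0.18 log units; that floor lies within the scatter). For compound 3 the expected value is 65000 nM, with an estimated range from 28000 nM to 150000 nM.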

Compound 3, half-maximal cytotoxic concentration: > 100000 nM
Compound 3: a limit, no number; the forecaster's own chance of this, stated with the estimate: 40%; middle value at least 1.5-fold (0.18 log units) away from the limit.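

In this assay compound 3 gives > 100000 nM and that is a limit of the assay, not a number. The step that puts trifluoromethyl in place of hydrogen on the phenyl cannot be read, because compound 2 and compound 3 both sit at the same limit: the limit of > 100000 nM in this assay, at which 2 of the 3 values shown sit. What can be read is the other change: with 4-(trifluoromethyl)phenyl kept, a group of 7 heavy atoms in place of a group of 3 heavy atoms on an aromatic carbon gives an at least 2.8-fold higher number from compound 1 to compound 3 (0.45 log units; beyond the scatter) and so lower toxicity in this test.

On these data alone, the true positions of compound 2 and compound 3 remain open, and with them any effect of trifluoromethyl on the group of 7 heavy atoms. Also open, as far as these compounds go, is whether another group in that same place on the phenyl, such as an amine or a carboxylic acid, would give a number rather than a limit.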